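From chloro to phenoxy on the shared core

The compounds below may be only part of what the source reports. "The series", "measured", "known", "first", "only" and "open" are said of these compounds alone.

In a physicochemical assay for lipophilicity (a lower number here means a more polar compound, a higher number a more lipophilic compound), compound 1 `Clc1cccc(Cl)c1C1=NC(c2ccccc2)CO1` gives 3.69, compound 2 `Fc1cccc(Cl)c1C1=NC(c2ccccc2)CO1` gives 3.45 and compound 3 `Clc1ccccc1C1=NC(c2ccccc2)CO1` gives 3.56. Compound 3 therefore lies within the scatter of both the others, and these numbers do not rank the three.

The next compound, compound 4 `c1ccc(Oc2ccccc2C2=NC(c3ccccc3)CO2)cc1`, carries phenoxy in place of chloro on an aromatic carbon, ortho to a large group: phenoxy in place of chloro on an aromatic carbon. The measured steps bear on this change only loosely. They are a number 0.13 log units lower from compound 1 to compound 3 (within the scatter), a number 0.11 log units higher from compound 2 to compound 3 (within the scatter) and a number 0.24 log units lower from compound 1 to compound 2 (within the scatter). Each exchanges only chloro, fluoro or hydrogen, none replaces the chloro that compound 4 loses, and none brings in a ring. They show how little the number moved for such small exchanges, but they do not measure a change of this size.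

Taking compound 3 at 3.56 as the starting point and weighing the added ring, a rise beyond the scatter is expected in this assay, much larger than any measured step. The estimated shift is a number 1.04 log units higher from compound 3 to compound 4 (beyond the scatter). For compound 4 the expected value is 4.6, with an estimated range from 4 to 5.2.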

Compound 4, partition coefficient: 5.61
Compound 4: middle estimate off by 1.01 log units, on the low side; measured number above the stated range.
By their numbers in this assay, from the lowest: compounds 2, 3 and 1 (each within the scatter of the next); then compound 4.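

In this assay, this place on an aromatic carbon, ortho to a large group, proved able to move the number far more than the earlier exchanges had suggested: phenoxy in place of chloro gives a number 2.05 log units higher from compound 3 to compound 4 (beyond the scatter), whereas the exchanges among chloro, fluoro and hydrogen all stayed within the scatter. The near-flat picture from the first three compounds therefore holds only for those small exchanges and does not extend to phenoxy, with its seven heavy atoms, six-membered aromatic ring and hydrogen-bond acceptor. Nothing measured here accounts for the size of this single step or separates the contributions of the parts of the entering group.

The compounds shown leave open whether methoxy, which keeps the oxygen without the ring, or phenyl, which keeps the ring without the oxygen, would move the number by a similar amount. They also leave open what an amine or a carboxylic acid would do at this place, and whether phenoxy would give a step of like size on the core of compound 1, with its second chloro kept.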